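Moving the methoxy group around the aryl ring

The compounds below may be only part of what the source reports. "The series", "measured", "known", "first", "only" and "open" are said of these compounds alone.

Compound 2 `COc1ccccc1-c1cc2nn(-c3ccccc3)c(N)c2c(=O)[nH]1` gives 15% in an assay on isolated protein for inhibition of RAC-alpha serine/threonine-protein kinase (Homo sapiens), read by mobility shift assay, tested at 30 uM (on this read-out lower numbers stand for less inhibition and higher numbers for more inhibition at the one concentration tested (going by the name of the read-out)), which is the higher of the two numbers seen so far; its nearest neighbour, compound 1 `Cc1cc2nn(-c3ccccc3)c(N)c2c(=O)[nH]1`, gives 5%, and the step of a number 10 percentage points higher from compound 1 to compound 2 (within the scatter) lies within the scatter. Compound 3 `COc1ccc(-c2cc3nn(-c4ccccc4)c(N)c3c(=O)[nH]2)cc1` differs from compound 2 by a rearrangement of the same atoms: 4-methoxyphenyl in place of 2-methoxyphenyl on an aromatic carbon. Going by the values given here, no measured step exchanges one methoxyphenyl for another, so the only step on record, a number 10 percentage points higher from compound 1 to compound 2 (within the scatter), tells merely that adding a 2-methoxyphenyl in place of methyl gave no move beyond the scatter. With nothing pointing either way, the author expects compound 3 to stay near compound 2, the estimated step being no change at the digits printed from compound 2 to compound 3 (within the scatter), within the scatter. Compound 3 is therefore estimated at 15%, with a range from 0% to 35%.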

Compound 3, a percentage reported as inhibition, at one concentration (the size of the read-out at that concentration, not a potency): 16%
For compound 3 the middle estimate is 1 percentage points below the measured one; low and high end bracket the measured number.
By their numbers in this assay, from the lowest: compounds 1, 2 and 3 (each within the scatter of the next, the first and the last beyond it).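

In this assay the exchange of 2-methoxyphenyl for 4-methoxyphenyl, on the aromatic carbon next to the ring nitrogen, brings a number 1 percentage points higher from compound 2 to compound 3 (within the scatter) and so shows no readable effect of where the methoxy group sits on the aryl ring. Going by these compounds alone, measured against methyl, 4-methoxyphenyl gives a number 11 percentage points higher from compound 1 to compound 3 (beyond the scatter) as the first modest step at this position to pass the scatter, yet this does not set the two methoxyphenyl groups apart, since compound 2 and compound 3 lie within the scatter of each other. Nothing measured here bears on why the numbers fall as they do.

The compounds shown leave open what 3-methoxyphenyl would give at this position. They also leave open whether an amine or a carboxylic acid on the aryl ring, or a longer chain in place of methyl, would move the inhibition further.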